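The source may report more compounds than this note shows. Statements on the series, on what has been measured and on what is new or still open speak of the compounds shown alone.

Compound 1 `CS(=O)(=O)c1cncc(-c2cnc3ccc(-c4cccc(S(=O)(=O)C5CC5)c4)nn23)c1` is one of the two compounds measured here in a physicochemical assay for solubility, at pH 2; on this read-out lower numbers stand for lower solubility and higher numbers for higher solubility. In this assay, among the compounds with values here, compound 1 gives 18000 nM, the only plain number reported. Compound 2 `CS(=O)(=O)c1cccc(-c2ccc3ncc(-c4ccc(S(=O)(=O)CCCN)cc4)n3n2)c1` is the other measured compound. For compound 2 the read-out in this assay is a limit, > 200000 nM, and not a number; this is the limit of > 200000 nM in this assay, at which 1 of the 2 values shown sits.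

Compound 3 `NC(=O)c1ccc(-c2cnc3ccc(-c4cccc(S(=O)(=O)C5CC5)c4)nn23)cc1` has not yet been measured. It differs from compound 1 in one place: 4-carbamoylphenyl in place of 5-(methylsulfonyl)pyridin-3-yl on an aromatic carbon. Within the data shown here, no measured pair of compounds in this set differs in just one place, so no measured step guides the change. The step from compound 1 to compound 3 in this assay is expected to be a 1.3-fold lower number from compound 1 to compound 3 (0.11 log units; within the scatter), which means no change beyond the usual scatter, or at most a slight lowering. Compound 3 is therefore expected to give about 14000 nM in this assay, with a likely range from 4000 nM to 50000 nM.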

Compound 3, solubility: 6300 nM
The estimate for compound 3 lay 2.2-fold (0.35 log units) above the measured number; measured number inside the range.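

Within the data shown here, compound 1 and compound 3 form the first pair here that differs in only one place, so they give the first direct reading of this position, an aromatic carbon of the five-membered aromatic ring. In this assay, putting 4-carbamoylphenyl in place of 5-(methylsulfonyl)pyridin-3-yl gives a 2.9-fold lower number from compound 1 to compound 3 (0.46 log units; beyond the scatter), which shows that the read-out responds to the group at this position. The swap alters several things at once, including the ring nitrogen, the hydrogen-bond donor count and the sulfonyl group, and nothing measured here points to a cause for the step.

On these data alone, it remains open how an amine or a carboxylic acid at this position would compare. A plain phenyl group there could help separate the contribution of the carbamoyl group from that of the ring change.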